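This account rests on a few compounds, and the source may have more. Where it says the series, first, only, none or still open, it means among the compounds named here.

Measured so far: compound 1 `C[C@H](Nc1nc(N)nc(N)c1C#N)c1cc2ccc(F)cn2c(=O)c1-c1ccccc1` gives 42% in an ADME assay on microsomes from liver (Mus musculus), read by LC-MS, using NADPH, with a stated time of 30 min, tested at 1 uM; on this read-out lower numbers stand for a less stable compound and higher numbers for a more stable compound; compound 2 `C[C@H](Nc1nc(N)nc(N)c1C#N)c1cc(=O)n2cc(F)ccc2c1-c1ccccc1` gives "not determined" (no result reported) in this assay; compound 3 `C[C@H](Nc1nc(N)nc(N)c1C#N)c1c(-c2ccccc2)c(=O)n2cc(F)ccc2c1C1CC1` gives 87%.

Going by the values given here, compound 3 stands highest of the two numbers, with a number 45 percentage points higher from compound 1 to compound 3 (beyond the scatter) as the only measured step, and compound 2 contributes no number. Compound 4 `C[C@H](Nc1nc(N)nc(N)c1C#N)c1c(-c2ccccc2)c(=O)n2cc(F)ccc2c1-c1ccc(C(N)=O)cc1` differs from compound 3 by 4-carbamoylphenyl in place of cyclopropyl on an aromatic carbon. Among the compounds with values here, the one measured step concerns cyclopropyl entering in place of hydrogen at this position; no measured step covers an aryl group entering in place of cyclopropyl, so the direction here rests on that single large step alone. For compound 4 a moderate drop is expected, a number 27 percentage points lower from compound 3 to compound 4 (beyond the scatter), landing at an estimated 60% with a range from 30% to 88%.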

Compound 4, percent of the compound remaining: 97%
Beside the measured number, compound 4's estimate is 37 percentage points below it; measured number outside the range, above it.
By their numbers in this assay, from the lowest: compound 1; then compounds 3 and 4 (each within the scatter of the next).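

In this assay this aromatic carbon takes the larger 4-carbamoylphenyl as well as cyclopropyl, with a number 10 percentage points higher from compound 3 to compound 4 (within the scatter) and with a number 55 percentage points higher from compound 1 to compound 4 (beyond the scatter). The high stability of compound 3 is therefore not specific to cyclopropyl among the groups shown here. No data on hand explain this result. What the carbamoyl group itself contributes remains open, since the compounds shown do not separate it from the phenyl ring. Also open, going by these compounds, is whether a carboxylic acid or an amine in its place would keep the number in this assay.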